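The source may report more compounds than this note shows. Statements on the series, on what has been measured and on what is new or still open speak of the compounds shown alone.

For the measured compounds named here, in an assay on isolated protein for inhibition of ribosomal protein S6 kinase alpha-2 (Homo sapiens), with a stated time of 150 min (on this read-out lower numbers stand for stronger inhibition and higher numbers for weaker inhibition), compound 3 `COc1ccccc1-c1cccc2nc(Nc3cc(OC)c(OC)c(OC)c3)oc12` gives 20 nM and stands second highest among the three numbers so far. Its nearest neighbour is compound 2 `COc1ccc(Nc2nc3cccc(-c4c(F)cccc4OC)c3o2)cc1O[C@H]1CCNC1`, which in this assay gives 10 nM, a gap that lies within the usual scatter of repeated measurements, so the two values cannot be put in order. Its furthest neighbour is compound 1 `COc1cccc(F)c1-c1cccc2nc(Nc3ccccc3)oc12`, which in this assay gives 1000 nM, a gap well beyond the scatter.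

Compound 4 `COc1cc(Nc2nc3cccc(-c4ccccc4-c4cn[nH]c4)c3o2)cc(OC)c1OC` is not yet measured. It differs from compound 3 in one place: 1H-pyrazol-4-yl in place of methoxy on an aromatic carbon. Going by the values given here, no step between measured compounds maps onto this change, so there is no direct precedent in the data for its size. On the numbers shown, compound 3 at 20 nM already sits among the lower values, and the replacement of a small group by a larger five-membered ring of uncertain consequence suggests a step that is expected to be small, most likely a 1.5-fold higher number from compound 3 to compound 4 (0.18 log units; within the scatter), and possibly none beyond the scatter. Compound 4 is therefore estimated to give about 30 nM in this assay, with a range from 8 nM to 120 nM.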

Compound 4, half-maximal inhibitory concentration: 9300 nM
Beside the measured number, compound 4's estimate is 310-fold (2.49 log units) below it; measured number outside the range, above it.
By their numbers in this assay, from the lowest: compounds 2 and 3 (each within the scatter of the next); then compound 1; then compound 4.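

In this assay, placing 1H-pyrazol-4-yl in place of methoxy on this aromatic carbon, ortho to a large group, gives a 470-fold higher number from compound 3 to compound 4 (2.67 log units; beyond the scatter), a large step well beyond the scatter. For the compounds shown here, this is the first step the series offers at this position, and it shows that the read-out can respond very strongly to what the position carries, at least for this one replacement. Nothing measured here accounts for the size of the step.

The compounds shown do not separate the effect of the five-membered aromatic ring itself from that of the hydrogen-bond donor it brings. A phenyl ring or an N-methylpyrazole on the same carbon would bear on that question, and a hydroxyl or an ethoxy group would show how the position responds to smaller changes from methoxy.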